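A few compounds are considered here, and "the series" means these few. Any claim that something is new, unique, unknown or untested is made for them only; others in the source may bear on it.

Compound 1 `Cn1cc(-c2cnc3c(-c4csc(C(=O)N[C@@H]5CCC[C@H]5O)c4)cnn3c2)cn1` gives 10 nM in an assay for inhibition of MAP/microtubule affinity-regulating kinase 3 (Homo sapiens), read by HTRF, with a stated time of 2 h; a higher number here means a weaker inhibitor, a lower number a stronger inhibitor.
Compound 2 `Cn1cc(-c2cnc3c(-c4csc(C(=O)N[C@@H]5CCC[C@@H]5N)c4)cnn3c2)cn1` gives 2 nM in this assay.
Compound 3 `Cn1cc(-c2cnc3c(-c4csc(C(=O)N[C@@H]5CCCC[C@@H]5O)c4)cnn3c2)cn1` gives 9 nM in this assay.

Compound 1 has the highest number of the three; compound 3 lies within the scatter of it, while compound 2 shows a 5.0-fold lower number from compound 1 to compound 2 (0.70 log units; beyond the scatter). Compound 4 `CCNC(=O)c1cc(-c2cnn3cc(-c4cnn(C)c4)cnc23)cs1` differs from compound 1 by ethyl in place of 2-hydroxycyclopentyl on an amide-type nitrogen. For the measured compounds named here, none of the measured steps removes the ring or the hydroxyl: a 1.1-fold lower number from compound 1 to compound 3 (0.05 log units; within the scatter) exchanges one hydroxylated ring for another, and a 4.5-fold higher number from compound 2 to compound 3 (0.65 log units; beyond the scatter) exchanges an amine-bearing ring for a hydroxylated one. Going by the values given here, with no precedent for ethyl at this position, a modest loss is expected for compound 4, a 3.0-fold higher number from compound 1 to compound 4 (0.48 log units; beyond the scatter) in this assay. Compound 4 is therefore estimated at 30 nM, with a range from 8 nM to 120 nM.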

Compound 4, half-maximal inhibitory concentration: 129 nM
Beside the measured number, compound 4's estimate is 4.3-fold (0.63 log units) below it; the measured number lies above the stated range.
By their numbers in this assay, from the lowest: compound 2; then compounds 3 and 1 (each within the scatter of the next); then compound 4.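

For the compounds shown here, exchanging the substituted ring for ethyl is the first step at this position that removes both the ring and its hydroxyl or amine, and in this assay it gives large losses (a 13-fold higher number from compound 1 to compound 4 (1.11 log units; beyond the scatter)) (a 14-fold higher number from compound 3 to compound 4 (1.16 log units; beyond the scatter)) (a 65-fold higher number from compound 2 to compound 4 (1.81 log units; beyond the scatter)). The exchanges among the ring-bearing groups were all much smaller, so on the amide-type nitrogen the change to ethyl matters far more than the difference between those groups. Nothing available gives a reason for this loss.

The compounds shown leave open whether the loss follows the ring or its hydroxyl or amine. An unsubstituted cyclopentyl group and a 2-hydroxyethyl or 2-aminoethyl chain would separate these.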